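Ring size at the amine: compound 3 to compound 4

The source may hold more compounds than are shown below. What is called first, only, known or untested is meant among the compounds shown, and "the series" means these compounds.

Measured so far in a functional assay on PC-3 cells (Homo sapiens) for antiproliferative activity, read by MTT assay, with a stated time of 72 h; on this read-out higher numbers stand for weaker inhibition and lower numbers for stronger inhibition:
compound 1 `C/C=C/C(=O)Nc1cc2c(N3CCCc4ccccc43)ncnc2cc1OC`: 7520 nM
compound 2 `CCC/C=C/C(=O)Nc1cc2c(N3CCCc4ccccc43)ncnc2cc1OC`: 2240 nM
compound 3 `CCN(CC)C/C=C/C(=O)Nc1cc2c(N3CCc4ccccc43)ncnc2cc1OC`: 3690 nM

Compound 3 holds the second highest of the three numbers; against compound 2 its value lies within the scatter, while against compound 1 the gap is beyond it. Compound 4 `CCN(CC)C/C=C/C(=O)Nc1cc2c(N3CCCc4ccccc43)ncnc2cc1OC` differs from compound 3 only in that (1,2,3,4-tetrahydroquinolin-1-yl in place of 2,3-dihydro-1H-indol-1-yl on an aromatic carbon). No measured pair isolates this ring change; the one shown step, a 3.4-fold lower number from compound 1 to compound 2 (0.53 log units; beyond the scatter), concerns the side chain instead and so offers no guide here. With nothing bearing directly on it, compound 4 is expected to stay near compound 3 in this assay, a step of a 1.3-fold lower number from compound 3 to compound 4 (0.12 log units; within the scatter) not beyond the scatter. Compound 4 is therefore estimated at 2800 nM, within 900 nM to 9000 nM.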

Compound 4, half-maximal inhibitory concentration: 6890 nM
Beside the measured number, compound 4's estimate is 2.5-fold (0.39 log units) below it; the measured number falls inside the stated range.
By their numbers in this assay, from the lowest: compounds 2, 3, 4 and 1 (each within the scatter of the next, the first and the last beyond it).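

In this assay, among these compounds, 1,2,3,4-tetrahydroquinolin-1-yl in place of 2,3-dihydro-1H-indol-1-yl gives the first direct reading at this aromatic carbon, a 1.9-fold higher number from compound 3 to compound 4 (0.27 log units; within the scatter), so this ring change is not resolved from the scatter. With 1,2,3,4-tetrahydroquinolin-1-yl held constant, diethylamino on the chain gives a 3.1-fold higher number from compound 2 to compound 4 (0.49 log units; beyond the scatter) against ethyl, while against hydrogen it gives a 1.1-fold lower number from compound 1 to compound 4 (0.04 log units; within the scatter). No evidence at hand accounts for these steps. Going by these compounds, whether morpholine in place of diethylamino would shift the number stays open, as does whether the ring change reads the same with the ethyl chain.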